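The source may hold more compounds than are shown below. What is called first, only, known or untested is meant among the compounds shown, and "the series" means these compounds.

Measured so far in a functional assay on MCF7 cells (Homo sapiens) for cytotoxicity, read by MTT assay, with a stated time of 48 h; a lower number here means a stronger inhibitor, a higher number a weaker inhibitor: compound 1 `[O-][S+](CCC(F)(Cl)C(F)(F)Cl)c1nc2ccccc2s1` gives 17100 nM. Compound 2 `FC(F)=C(F)CCSc1nccs1` reaches only the limit > 120000 nM. Compound 3 `FC(F)=C(F)CCSc1ncc(-c2ccncc2)s1` likewise reaches only the limit > 120000 nM.

Compound 3 thus stands at the limit of this assay, where the limit of > 120000 nM in this assay, at which 2 of the 3 values shown sit, places it, and no number is known for it. Among the compounds with values here, the one measured step, a step that the two limits leave unreadable from compound 2 to compound 3, is unreadable because a step that the two limits leave unreadable from compound 2 to compound 3 runs between two limits. Compound 4 `FC(F)=C(F)CCSc1ncc(Cl)s1` differs from compound 3 by chloro in place of pyridin-4-yl on an aromatic carbon. Within the data shown here, no measured step bears on this change. Compound 4 is expected to remain at or near the limit, with the step of a number no higher from compound 3 to compound 4 (the limit leaves the size open) of no readable size. The estimate for compound 4 in this assay is 120000 nM, within 40000 nM to 300000 nM.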

Compound 4, half-maximal inhibitory concentration: > 120000 nM
Compound 4 was reported as a limit; the forecaster's own chance of this, stated with the estimate: 80%; the middle value sits exactly at the limit.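

In this assay compound 4 gives > 120000 nM, a limit and not a number, so the steps to it from compound 2 and compound 3 cannot be read. The compounds shown leave open whether hydrogen, pyridin-4-yl and chloro on that aromatic carbon differ at all.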